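The source may report more compounds than this note shows. Statements on the series, on what has been measured and on what is new or still open speak of the compounds shown alone.

Working notes on the series. Compound 1 is `COC(=O)c1c(Nc2ccc(OC)cc2)sc(C(=O)c2ccc(OC)cc2)c1C`, compound 2 is `COC(=O)c1c(Nc2ccc(F)cc2)sc(C(=O)c2ccc(OC)cc2)c1C` and compound 3 is `COC(=O)c1c(Nc2ccc(Cl)cc2)sc(C(=O)c2ccc(OC)cc2)c1C`. In a functional assay, with a stated time of 150 min, tested at 30 ug/mL (on this read-out higher numbers stand for a stronger effect at the one concentration tested and lower numbers for a weaker effect), compound 1 gives 20.5%. In this assay compound 2 gives 23.3%; the step of a number 2.8 percentage points higher from compound 1 to compound 2 (within the scatter) stays within the scatter. In this assay, among the compounds with values here, compound 3 is reported as "not active" (no number reported), without a number, so where compound 3 stands relative to compound 1 and compound 2 cannot be placed on the scale, and no step from it can be stated.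

Compound 4 is `COC(=O)c1c(Nc2ccc(Cl)cc2)sc(C(=O)c2ccc(C)cc2)c1C`. Against compound 3 the difference is methyl in place of methoxy on an aromatic carbon; read one bond further out, 4-methoxyphenyl becomes 4-methylphenyl. Within the data shown here, no measured step concerns methyl in place of methoxy on an aromatic carbon: the single known step, a number 2.8 percentage points higher from compound 1 to compound 2 (within the scatter), is a different exchange at a different place and is itself within the scatter, so it carries nothing over to this change. No direction beyond the scatter can therefore be argued for compound 4 in this assay. Among the measured compounds shown here, the only anchor is that compound 3 is reported as "not active" (no number reported), so a low read-out, possibly again without a number, is expected for compound 4. Compound 4 is estimated at 12% in this assay, with a range from 0% to 30%.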

Compound 4, a percentage reported as activity, at one concentration (the size of the read-out at that concentration, not a potency): "not active" (no number reported)
No number was reported for compound 4; the estimate stays without a comparison.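

In this assay, within the data shown here, compound 3 stands as "not active" (no number reported) and compound 4 as "not active" (no number reported), so no step between them can be read. No supporting measurement bears on this result. The compounds shown leave open whether 4-methoxyphenyl and 4-methylphenyl differ in effect when the read-out carries a number.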